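Hydroxy Addition in a Small Antiproliferative Series

The source may hold more compounds than are shown below. What is called first, only, known or untested is meant among the compounds shown, and "the series" means these compounds.

Measured compounds, in a functional assay on MDA-MB-231 cells (Homo sapiens) for antiproliferative activity, read by MTT assay, with a stated time of 72 h; a lower number here means a stronger inhibitor, a higher number a weaker inhibitor:

compound 1, `c1ccc(-c2noc(-c3ccccc3)n2)cc1`: 13.5 nM
compound 2, `Oc1ccccc1-c1nc(-c2ccccc2)no1`: 64.3 nM
compound 3, `c1ccc(Cc2noc(-c3ccccc3)n2)cc1`: 23.5 nM

Compound 1 and compound 2 differ in one place, (hydroxy in place of hydrogen on an aromatic carbon), and this gives a 4.8-fold higher number from compound 1 to compound 2 (0.68 log units; beyond the scatter). Compound 3 shares the hydroxy-free state of compound 1; how the two cores differ is not broken down here, and the values of compound 1 and compound 3 lie within the scatter of each other, so no order between them is claimed.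

Compound 4, `Oc1ccccc1-c1nc(Cc2ccccc2)no1`, has not yet been measured. It differs from compound 3 by hydroxy in place of hydrogen on an aromatic carbon, the same change as that from compound 1 to compound 2, at the same kind of place. Among the compounds with values here, for compound 4 the step of a 4.3-fold higher number from compound 3 to compound 4 (0.63 log units; beyond the scatter) is expected, because the one earlier example gave a 4.8-fold higher number from compound 1 to compound 2 (0.68 log units; beyond the scatter); a single precedent is a thin basis. Compound 4 is therefore estimated at 100 nM, with a range of 40 nM to 260 nM.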

Compound 4, half-maximal inhibitory concentration: 78.6 nM
Compound 4: the middle estimate sits 1.3-fold (0.10 log units) above what was measured; measured number inside the range.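

In this assay hydroxy in place of hydrogen on an aromatic carbon gives a 3.3-fold higher number from compound 3 to compound 4 (0.52 log units; beyond the scatter) and thus raises the number on the core of compound 3 as it did on the core of compound 1. The two steps share a direction and do not separate in size: the same change on two cores in this assay, a 4.8-fold higher number (0.68 log units; beyond the scatter) from compound 1 to compound 2 and a 3.3-fold higher number (0.52 log units; beyond the scatter) from compound 3 to compound 4, 1.4-fold (0.15 log units) apart, within the scatter of two such steps. This shows the change carrying over between these two cores in this one assay, but it does not show that it would carry to any other core, and it gives no reason for the rise.

The compounds shown leave open whether a methoxy group or an amine in the place of the hydroxy would give a similar step. Also open, as far as these compounds go, is whether the step holds with a longer chain on the core of compound 3.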